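Changing the aryl group on a urea inhibitor

This account rests on a few compounds, and the source may have more. Where it says the series, first, only, none or still open, it means among the compounds named here.

Three compounds have been measured in an assay on microsomes from intestine for inhibition of acyl-CoA:cholesterol acyltransferase (Oryctolagus cuniculus); a higher number here means a weaker inhibitor, a lower number a stronger inhibitor:

Compound 1, `CC(C)c1cccc(C(C)C)c1NC(=O)NCc1ccccc1`, gives 360 nM.
Compound 2, `CC(C)c1cccc(C(C)C)c1NC(=O)NCCC(c1ccccc1)c1ccccc1`, gives 140 nM.
Compound 3, `Cc1cccc(NC(=O)NCC2(c3ccccc3)CCCCC2)c1`, gives 2800 nM.

Compound 3 gives the highest number of the three in this assay and is therefore the weakest inhibitor shown. Its nearest neighbour is compound 1, and the gap between them is beyond the scatter of repeated measurements; the gap to compound 2 is larger still. The unmeasured compound 4, `O=C(NCC1(c2ccccc2)CCCCC1)Nc1ccc(I)cc1`, differs from compound 3 in one place: 4-iodophenyl in place of 3-methylphenyl on an amide-type nitrogen. Among the compounds with values here, no pair of measured compounds shows this particular exchange, so there is no measured step to lean on, and compounds 1 and 2 carry a quite different group on that nitrogen. The direction of the change is therefore open. The expected step is a 1.4-fold lower number from compound 3 to compound 4 (0.15 log units; within the scatter), a small move that may not exceed the usual scatter. Compound 4 is thus expected to give 2000 nM, with a range from 600 nM to 6500 nM.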

Compound 4, half-maximal inhibitory concentration: 2300 nM
Compound 4: the middle estimate sits 1.2-fold (0.06 log units) below what was measured; low and high end bracket the measured number.
By their numbers in this assay, from the lowest: compound 2; then compound 1; then compounds 4 and 3 (each within the scatter of the next).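

Within the data shown here, this is the first measured exchange at this place, on an amide-type nitrogen: 4-iodophenyl in place of 3-methylphenyl gives a 1.2-fold lower number from compound 3 to compound 4 (0.09 log units; within the scatter) in this assay. With the rest of the molecule unchanged, these two aryl groups, each of 7 heavy atoms, cannot be told apart, so this exchange gives no direction for the position. Nothing measured here bears on the reason for this result.

Still open, as far as these compounds go, is whether the position stays this indifferent with other groups, such as a phenyl ring carrying a carboxylic acid or an amine, or a pyridine ring in place of the phenyl ring. From the compounds shown here alone, it is also open what the 2,6-diisopropylphenyl group of compounds 1 and 2 would give on the core of compound 3, since no single exchange links those compounds.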